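Triazole in place of methoxy on an enone core

The source may hold more compounds than are shown below. What is called first, only, known or untested is meant among the compounds shown, and "the series" means these compounds.

The study covers three measured compounds and one that awaits measurement. Compound 1 `CC(=O)OC/C1=C/C[C@](C)(CCC=C(C)C)/C=C/[C@@H](OC(=O)C=C(C)C)[C@](C)(O)/C=C/C1=O` gives 2950 nM in a functional assay on HL-60 cells (Homo sapiens) for antiproliferative activity, read by MTT assay, with a stated time of 48 h; on this read-out lower numbers stand for stronger inhibition and higher numbers for weaker inhibition. Compound 2 `COC/C1=C/C[C@](C)(CCC=C(C)C)/C=C/[C@@H](OC(=O)C=C(C)C)[C@](C)(O)/C=C/C1=O` gives 3070 nM in this assay and is the highest of the two numbers shown, with compound 1 as its nearest neighbour; the step of a 1.0-fold higher number from compound 1 to compound 2 (0.02 log units; within the scatter) is the only single-point change measured so far. For the measured compounds named here, compound 3 `CC(C)=CCC[C@]1(C)/C=C/[C@@H](OC(=O)C=C(C)C)[C@](C)(O)CCC(=O)/C(CO)=C\C1` is reported only as a limit of > 40000 nM in this assay; it differs from compound 2 in more than one place, so no step is counted to it.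

Compound 4 `CC(C)=CCC[C@]1(C)/C=C/[C@@H](OC(=O)C=C(C)C)[C@](C)(O)/C=C/C(=O)/C(Cn2cc(CO)nn2)=C\C1` is the compound still to be measured. It differs from compound 2 by 4-(hydroxymethyl)-1H-1,2,3-triazol-1-yl in place of methoxy on a saturated chain carbon bound to a double-bonded ring carbon. Going by the values given here, the measured step from compound 1 to compound 2 sits at the same oxygen position and stayed within the scatter, but no measured step covers the entry of a ring there. Compound 4 is therefore expected to land near compound 2, with a modest move toward a higher number allowed, as a 1.5-fold higher number from compound 2 to compound 4 (0.17 log units; within the scatter). The estimate for compound 4 is 4500 nM, in the range 1500 nM to 15000 nM.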

Compound 4, half-maximal inhibitory concentration: 3200 nM
Estimate against measurement, compound 4: 1.4-fold (0.15 log units) above; low and high end bracket the measured number.
By their numbers in this assay, from the lowest: compounds 1, 2 and 4 (each within the scatter of the next). At a limit, above all of these: compound 3.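

On a saturated chain carbon bound to a double-bonded ring carbon, 4-(hydroxymethyl)-1H-1,2,3-triazol-1-yl takes the place of methoxy in this assay with a 1.0-fold higher number from compound 2 to compound 4 (0.02 log units; within the scatter). Set against acetoxy at the same place, the same group gives a 1.1-fold higher number from compound 1 to compound 4 (0.04 log units; within the scatter), so the earlier compounds' agreement, which covered only two groups without a ring, now extends to a group with a five-membered aromatic ring with 3 hetero atoms. Nothing measured among the compounds shown accounts for this agreement.

As far as these compounds go, what a triazole bearing an amine or a carboxylic acid in place of the hydroxymethyl would give at this place stays open, as does a longer chain linking the ring to the core. Compound 3 is reported only as a limit and differs from compound 2 in more than one place, so it settles neither question.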